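Cyclopropyl for bromo on the fused ring

A few compounds are considered here, and "the series" means these few. Any claim that something is new, unique, unknown or untested is made for them only; others in the source may bear on it.

Measured so far:
compound 1 `CC(C)(C)c1cc(NC(=O)Nc2ccc(-c3cn4cc(Cl)ccc4n3)cc2)no1` gives 24.8 nM in a functional assay on MV4-11 cells (Homo sapiens) for cytotoxicity, read by MTT assay, with a stated time of 72 h; a lower number here means a stronger inhibitor, a higher number a weaker inhibitor
compound 2 `CC(C)(C)c1cc(NC(=O)Nc2ccc(-c3cn4cc(Br)ccc4n3)cc2)no1` gives 44.5 nM in this assay

Within the data shown here, compound 2 has the highest of the two numbers in this assay; its nearest neighbour is compound 1, and the only step so far, a 1.8-fold higher number from compound 1 to compound 2 (0.25 log units; within the scatter), is within the scatter, so the two compounds cannot be ordered. The next compound, compound 3 `CC(C)(C)c1cc(NC(=O)Nc2ccc(-c3cn4cc(C5CC5)ccc4n3)cc2)no1`, differs from compound 2 by cyclopropyl in place of bromo on an aromatic carbon. Among the measured compounds shown here, no measured step covers a halogen giving way to a carbon ring at this place; the one step in hand, from chloro to bromo, is small, which says only that this position tolerates a change of halogen without a shift beyond the scatter. Nothing in hand argues for a directional step. The expectation for compound 3 is therefore a 1.0-fold higher number from compound 2 to compound 3 (0.00 log units; within the scatter), that is, a number close to compound 2 in this assay. As far as these compounds go, compound 3 is estimated at 45 nM, with a range of 14 nM to 150 nM, the width reflecting that the change is untested.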

Compound 3, half-maximal inhibitory concentration: 15.8 nM
Compound 3: middle estimate off by 2.8-fold (0.45 log units), on the high side, and the stated range covers the measured number.
By their numbers in this assay, from the lowest: compounds 3, 1 and 2 (each within the scatter of the next, the first and the last beyond it).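

In this assay, among these compounds, cyclopropyl in place of bromo gives a 2.8-fold lower number from compound 2 to compound 3 (0.45 log units; beyond the scatter), the only step at this position beyond the scatter, so this position does respond to the group it carries and can hold a three-membered ring of carbon as well as a halogen. Cyclopropyl in place of chloro gives a 1.6-fold lower number from compound 1 to compound 3 (0.20 log units; within the scatter), within the scatter, so compound 1 and compound 3 cannot be ordered, and the step from bromo does not extend to halogens in general, with chloro going against it. Nothing on hand bears on the reason for the step from bromo.

Open, as far as these compounds go, is whether the ring itself matters or simply carbon at this position, which a methyl, an isopropyl or a cyclobutyl group would address. Also open, from the compounds shown here alone, is how this position would respond to an amine or a methoxy group.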